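Replacing Cyclohexyl with Isobutyl on a Chalcone Ether

A few compounds are considered here, and "the series" means these few. Any claim that something is new, unique, unknown or untested is made for them only; others in the source may bear on it.

Compound 1 `O=C(/C=C/c1ccc(O)cc1)c1c(O)cccc1OCC1CCCCC1` carries a cyclohexylmethoxy group on the shared core. In a functional assay on PC-3 cells (Homo sapiens) for antiproliferative activity, read by sulforhodamine B assay (a lower number here means a stronger inhibitor of growth, a higher number a weaker inhibitor of growth), compound 1 gives > 30000 nM, which is a limit of the assay and not a number. Compound 1 thus stands at the limit of > 30000 nM in this assay, at which 2 of the 3 values shown sit. Among the compounds with values here, its nearest measured neighbour, compound 2 `O=C(/C=C/c1ccc(O)cc1)c1c(O)cccc1OCCC1CCCC1`, gives 3480 nM in this assay, and the step of an at least 8.6-fold lower number from compound 1 to compound 2 (0.93 log units; beyond the scatter) is the only measured step that touches the same place on the chain. Compound 3 `CC(C)(C)CCOc1cccc(O)c1C(=O)CCc1ccc(O)cc1`, which has a saturated linker in place of the enone, gives > 30000 nM in this assay, again a limit and not a number.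

Compound 4 `CC(C)CCOc1cccc(O)c1C(=O)/C=C/c1ccc(O)cc1` differs from compound 1 by isobutyl in place of cyclohexyl on a saturated chain carbon bound to an oxygen on an aromatic ring. The step from compound 1 to compound 2 shows that changing the group at this place can move the number beyond the scatter, but that step kept a ring and lengthened the chain, whereas here the ring is lost and the group becomes smaller. Going by these compounds, because compound 1 sits at the limit of > 30000 nM in this assay, at which 2 of the 3 values shown sit, the true starting point is unknown, and so is the direction of any move. Compound 4 is expected to give 15000 nM in this assay, with a range from 4000 nM to 60000 nM. This estimate amounts to an expected step of an at least 2.0-fold lower number from compound 1 to compound 4 (0.30 log units; that floor lies within the scatter), small at most and uncertain in direction.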

Compound 4, concentration for 50% growth inhibition: 11500 nM
The estimate for compound 4 lay 1.3-fold (0.12 log units) above the measured number, and the stated range covers the measured number.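

Losing the ring at this place gives an at least 2.6-fold lower number from compound 1 to compound 4 (0.41 log units; beyond the scatter), so a ring on this chain is not needed for a measurable number in this assay. A ring is not the better choice here either, as the open chain gives up ground against the cyclopentyl group with a 3.3-fold higher number from compound 2 to compound 4 (0.52 log units; beyond the scatter), and compound 4 thus falls on the far side of compound 2 from compound 1, so the presence of a ring alone does not order these three compounds. Compound 1 remains a limit of the assay and not a number, so the first of these steps is only a floor: the limit of > 30000 nM in this assay, at which 2 of the 4 values shown sit.

The compounds shown leave open how a cyclobutyl group or a longer chain, such as a hexyl chain, would stand at this place against cyclopentyl and isopropyl. They also leave open whether an amine or a hydroxyl group at the end of the isopentyl chain would move the number in either direction.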